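Swapping the Amide Substituent in a Cytotoxicity Series

The source may report more compounds than this note shows. Statements on the series, on what has been measured and on what is new or still open speak of the compounds shown alone.

Compound 1, `O=C(NCc1ccncc1)C1CCN(C(=O)c2cc3ccccc3n2Cc2ccc(Cl)cc2)CC1`: in an ADME assay on BE(2)-C cells (Homo sapiens) for cytotoxicity, read by MTT assay, with a stated time of 20 h (a higher number here means that more compound is tolerated, a lower number that less compound is tolerated), compound 1 gives > 100000 nM, which is a limit of the assay and not a number.
Compound 2, `CC(NC(=O)C1CCN(C(=O)c2cc3ccccc3n2Cc2ccc(Cl)cc2)CC1)c1ccncc1`: in this assay compound 2 gives 90100 nM.
Compound 3, `CN1CCC(CNC(=O)C2CCN(C(=O)c3cc4ccccc4n3Cc3ccc(Cl)cc3)CC2)CC1`: in this assay compound 3 gives > 50000 nM, again a limit of the assay rather than a number.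

Compound 2 therefore stands as the only one of the three with a true number; the other two entries are limits, the limit of > 100000 nM in this assay, at which 1 of the 3 values shown sits, and (the limit of > 50000 nM in this assay, at which 1 of the 3 values shown sits). The step of an at least 1.1-fold lower number from compound 1 to compound 2 (0.04 log units; that floor lies within the scatter) lies within the scatter, and the steps a step that the two limits leave unreadable from compound 1 to compound 3 and a step that the limit leaves unreadable from compound 2 to compound 3 cannot be read from the limits.

Compound 4, `Cn1cnc(CNC(=O)C2CCN(C(=O)c3cc4ccccc4n3Cc3ccc(Cl)cc3)CC2)c1`, differs from compound 2 by (1-methyl-1H-imidazol-4-yl)methyl in place of 1-(pyridin-4-yl)ethyl on an amide-type nitrogen. The change sits on the same amide-type nitrogen as the unreadable step that the limit leaves unreadable from compound 2 to compound 3, so nothing beyond the scatter is expected in this assay. Compound 4 is expected to give about 100000 nM, between 40000 nM and 250000 nM. The step from compound 2 is estimated as a 1.1-fold higher number from compound 2 to compound 4 (0.05 log units; within the scatter).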

Compound 4, half-maximal cytotoxic concentration: > 50000 nM
Compound 4 gave a limit, no number; the forecaster's own chance of this, stated with the estimate: 55%; the middle value lies beyond the limit too.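

In this assay, among the compounds shown here, compound 4 gives > 50000 nM, a limit and not a number, so no step linking it to compound 1, compound 2 or compound 3 can be read. The compounds shown leave open whether swapping the amide substituent changes cytotoxicity in this series at all.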